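The compounds below may be only part of what the source reports. "The series", "measured", "known", "first", "only" and "open" are said of these compounds alone.

Measured in an ADME assay on HepG2 2.2.15 cells (Homo sapiens) for cytotoxicity; a higher number here means that more compound is tolerated, a lower number that less compound is tolerated:
- Compound 1 `CC12CCC(C(=O)OCCc3c(-c4ccccc4Cl)c4cc(Cl)ccc4[nH]c3=O)(OC1=O)C2(C)C`: > 1800000 nM (a limit)
- Compound 2 `O=C(OCCc1c(-c2ccccc2Cl)c2cc(Cl)ccc2[nH]c1=O)c1ccccc1`: 43000 nM
- Compound 3 `COc1cccc(/C=C/C(=O)OCCc2c(-c3ccccc3Cl)c3cc(Cl)ccc3[nH]c2=O)c1`: > 1300000 nM (a limit)

Compound 3 stands at the limit of > 1300000 nM in this assay, at which 1 of the 3 values shown sits, so its true value is not known. Compound 4 `O=C(/C=C/c1ccc(C(F)(F)F)cc1)OCCc1c(-c2ccccc2Cl)c2cc(Cl)ccc2[nH]c1=O` is made from compound 3 by one change: 4-(trifluoromethyl)phenyl in place of 3-methoxyphenyl on a double-bonded chain carbon bound to a double-bonded chain carbon. It therefore keeps the ethenyl chain on the carbonyl carbon.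

Going by the values given here, no measured step changes this aromatic ring, so the evidence is indirect. The closest comparison is an at least 30-fold higher number from compound 2 to compound 3 (1.48 log units; beyond the scatter), a large step that adds the 2-(3-methoxyphenyl)ethenyl group in place of phenyl. Compound 1 also differs widely from compound 2, with an at least 41-fold lower number from compound 1 to compound 2 (1.62 log units; beyond the scatter). In contrast, a step that the two limits leave unreadable from compound 1 to compound 3 cannot be sized.

Compound 4 should therefore stay much nearer compound 3 than compound 2, with a modest drop at most, and the assay may again report only a limit. The step expected is an at least 1.8-fold lower number from compound 3 to compound 4 (0.26 log units; that floor lies within the scatter). The estimated value for compound 4 is 700000 nM, with an expected range from 60000 nM to 2000000 nM.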

Compound 4, half-maximal cytotoxic concentration: > 1400000 nM
Compound 4 ended at the assay's limit; the forecaster's own chance of this, stated with the estimate: 55%; at least 2.0-fold (0.30 log units) between middle value and limit.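

In this assay there is an at least 32-fold higher number from compound 2 to compound 4 (1.51 log units; beyond the scatter). The large rise seen with 2-(3-methoxyphenyl)ethenyl in compound 3 therefore also appears with 2-(4-(trifluoromethyl)phenyl)ethenyl, so among these compounds it does not depend on one particular ring on the chain. Compound 4 gives > 1400000 nM, which is a limit, and the steps from compound 1 and compound 3 to compound 4 cannot be read, so no order among these three compounds can be stated.

On these data alone, it remains open whether the ethenyl chain alone accounts for the difference from compound 2, or whether the groups on its ring also contribute. A plain 2-phenylethenyl or 2-phenylethyl group on the carbonyl carbon, or a ring carrying an amine or a carboxylic acid, would test this.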